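Swapping the ester for a urea on a biaryl scaffold

The source may report more compounds than this note shows. Statements on the series, on what has been measured and on what is new or still open speak of the compounds shown alone.

Measured so far:
- compound 1, `CCOC(=O)c1cccc(-c2ccc(OCC)cc2)c1`, 87%
- compound 2, `CCOC(=O)c1cccc(-c2ccc(N(C)C)cc2)c1`, 87%
- compound 3, `CCOC(=O)c1cccc(-c2ccc(C(C)N(C)C)cc2)c1`, 50%

For the measured compounds named here, in an assay on COS-7 cells for inhibition of patatin-like phospholipase domain-containing protein 2 (Mus musculus), tested at 200 uM (on this read-out higher numbers stand for more inhibition at the one concentration tested (going by the name of the read-out) and lower numbers for less inhibition), compound 2 gives 87%, level with compound 1 and together with it the highest of the three numbers; the only clearly different value is that of compound 3, as the step of a number 37 percentage points lower from compound 2 to compound 3 (beyond the scatter) shows. Compound 4, `CN(C)C(=O)N(C)c1cccc(-c2ccc(N(C)C)cc2)c1`, keeps the dimethylamino group of compound 2 and changes the other ring instead: (dimethylcarbamoyl)(methyl)amino in place of ethoxycarbonyl on an aromatic carbon. Going by the values given here, none of the measured steps touches this part of the molecule; the steps of no change at the digits printed from compound 1 to compound 2 (within the scatter) and a number 37 percentage points lower from compound 1 to compound 3 (beyond the scatter) concern only the substituent on the far ring. So nothing measured tells how much the ester contributes. Because compound 2 gives 87% and the change removes a group present in all three measured compounds, a drop is expected, of uncertain size. The expected step is a number 37 percentage points lower from compound 2 to compound 4 (beyond the scatter), giving an estimated 50% for compound 4, in the range 15% to 80%.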

Compound 4, a percentage reported as inhibition, at one concentration (the size of the read-out at that concentration, not a potency): 74%
Beside the measured number, compound 4's estimate is 24 percentage points below it; low and high end bracket the measured number.
By their numbers in this assay, from the lowest: compound 3; then compound 4; then compounds 1 and 2 (each within the scatter of the next).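

This is the first change shown on the ring that carries the ethoxycarbonyl group, and in this assay it gives a number 13 percentage points lower from compound 2 to compound 4 (beyond the scatter). The step lies beyond the scatter but is modest, so in this pair the ester is not needed for a substantial read-out: compound 4, with (dimethylcarbamoyl)(methyl)amino in its place, still gives 74% at the one concentration tested. Nothing available accounts for the size of this step.

From the compounds shown here alone, how a carboxylic acid or a simple primary amide would fare in the same place remains open. Also open is whether this swap would have a similar effect on a compound carrying ethoxy in place of dimethylamino, and the single-concentration read-out gives no potency for any of these compounds.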